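The source may hold more compounds than are shown below. What is called first, only, known or untested is meant among the compounds shown, and "the series" means these compounds.

Compound 1 `FC(F)(F)c1ccccc1Nc1nc(-c2ccncc2)cs1` is the weakest of the compounds with a single number in a functional assay on RCC4 cells (Homo sapiens) for inhibition, read by XTT assay, with a stated time of 4 days; a lower number here means a stronger inhibitor, a higher number a weaker inhibitor: in this assay compound 1 gives 40700 nM. Its nearest neighbour on the numbers is compound 3 `CCc1cnccc1-c1csc(Nc2cccc(C)c2)n1`, which in this assay gives 6310 nM, a gap that lies beyond the scatter. Further away stands compound 2 `Cc1cccc(Nc2nc(-c3ccncc3-c3ccc(S(C)(=O)=O)cc3)cs2)c1`, whose repeated readings in this assay agree closely (the several entries of compound 2 in this assay, 1600 nM; 1620 nM (2 entries)), compound 2 giving 1600 nM; 1620 nM (2 entries). Compound 4 `Oc1ccccc1Nc1nc(-c2ccncc2)cs1` has not yet been measured in this assay. It differs from compound 1 in one place (hydroxy in place of trifluoromethyl on an aromatic carbon). Going by the values given here, no measured pair in the set shows what this exchange does. The change removes the largest substituent on that ring of compound 1 and puts a small group in its place, and the closest comparison available is simply that compound 1 sits at the high end of the numbers, so there is room for the number to fall. A modest step toward a lower number, of a size only a little beyond the scatter, is expected from compound 1 to compound 4 (a 2.3-fold lower number from compound 1 to compound 4 (0.35 log units; beyond the scatter)). Compound 4 is therefore estimated at 18000 nM in this assay, within a range from 5000 nM to 70000 nM.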

Compound 4, half-maximal inhibitory concentration: 12900 nM
Compound 4: the middle estimate sits 1.4-fold (0.14 log units) above what was measured; the range from low to high includes it.
By their numbers in this assay, from the lowest: compound 3; then compound 4; then compound 1.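

The exchange of hydroxy for trifluoromethyl gives the set its first pair of compounds that differ in one place, and in this assay it gives a 3.2-fold lower number from compound 1 to compound 4 (0.50 log units; beyond the scatter). At this place, ortho to a large group, a substituent of 4 heavy atoms and no hydrogen-bond donor can thus give way to one of 1 heavy atom and 1 hydrogen-bond donor with a modest lowering of the number. Nothing measured here accounts for that step.

With one pair, the compounds shown cannot separate the loss of heavy atoms from the arrival of the hydrogen-bond donor. Also open, as far as these compounds go, is how an amine, a methoxy group or a fluorine at this same place would compare with hydroxy and trifluoromethyl.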